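A few compounds are considered here, and "the series" means these few. Any claim that something is new, unique, unknown or untested is made for them only; others in the source may bear on it.

In an ADME assay (Rattus norvegicus, strain Han-wistar) for metabolic stability, at a dose of 1.5 umol/kg by the intravenous route (on this read-out higher numbers stand for a longer-lived compound and lower numbers for a shorter-lived compound), compound 1 (`CC(C)n1cc(-c2ccnc3[nH]c(C4CCN(CC(=O)N5CCCC5)CC4)cc23)ccc1=O`) gives 1.1 h and compound 2 (`CC(C)n1nc(-c2ccnc3[nH]c(C4CCN(CC(=O)N(C)C)CC4)cc23)ccc1=O`) gives 1 h while compound 3 (`COc1cc(C(=O)N2CCCC2)ccc1-c1ccnc2[nH]c(C3CCOCC3)cc12`) gives 0.5 h on the same read-out. Compound 2 at 1 h lies within the usual scatter of both other compounds, so these numbers do not set the three apart. Compound 4 (`CC(C)n1cc(-c2ccnc3[nH]c(C4CCN(CC(=O)N(C)C)CC4)cc23)ccc1=O`) is compound 2 with a single change (a group of 10 heavy atoms (8 carbon, 1 nitrogen, 1 oxygen; one six-membered aromatic ring with 1 hetero atom) in place of a group of 10 heavy atoms (7 carbon, 2 nitrogen, 1 oxygen; one six-membered aromatic ring with 2 hetero atoms), on an aromatic carbon) on an aromatic carbon opposite the ring nitrogen. One six-membered aromatic ring with 2 hetero atoms leaves and one with 1 hetero atom enters. For the measured compounds named here, no measured pair shows directly what this swap does. The entering group also stands on compound 1 at 1.1 h and that number lies within the scatter of compound 2, so no change beyond the scatter is expected in this assay in either direction. The expected size is no change at the digits printed from compound 2 to compound 4 (within the scatter) and this estimate stays within the scatter. For compound 4 the estimated half-life is 1 h with an expected range from 0.5 h to 2 h in repeat measurements.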

Compound 4, half-life: 1.7 h
Estimate against measurement, compound 4: 1.7-fold (0.23 log units) below; the measured number falls inside the stated range.
By their numbers in this assay, from the lowest: compounds 3, 2, 1 and 4 (each within the scatter of the next, the first and the last beyond it).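

Replacing the ring with two hetero atoms by the ring with one, on the aromatic carbon opposite the ring nitrogen, can now be read directly in this assay: the swap gives a 1.7-fold higher number from compound 2 to compound 4 (0.23 log units; within the scatter), so the half-life shows no clear response to this change. The amide end can be read as well, since dimethylamino in place of pyrrolidin-1-yl on a carbonyl carbon gives a 1.5-fold higher number from compound 1 to compound 4 (0.19 log units; within the scatter), and neither step is large enough to separate the compounds. Nothing measured here bears on why the steps come out this way.

From the compounds shown here alone, whether a plain phenyl ring or a ring carrying a carboxylic acid at this position would move the half-life beyond the scatter remains open. The same is true of a morpholine on the carbonyl carbon.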